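The compounds below may be only part of what the source reports. "The series", "measured", "known", "first", "only" and "open" are said of these compounds alone.

Three related compounds have so far been measured in an ADME assay on L6 cells (Rattus norvegicus) for cytotoxicity; a lower number here means a stronger inhibitor, a higher number a weaker inhibitor. Compound 1 (`COc1ccc(C2CC3(N(C)C)CC(O)C2C(c2ccc(OC)cc2)C3)cc1`) gives 63400 nM, compound 2 (`CN(C)C12CC(O)C(C(c3ccc(Cl)cc3)C1)C(c1ccc(Cl)cc1)C2`) gives 8770 nM, and compound 3 (`CN(C)C12C/C(=N\O)C(C(c3ccccc3)C1)C(c1ccccc1)C2`) gives 150000 nM. Compound 3 therefore has the highest number of the three, and its distance from both compound 1 and compound 2 lies beyond the usual scatter, which makes it the weakest inhibitor of the set in this assay. No two of these compounds differ in only one place, so the data offer no direct measure of what a single change does here.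

Compound 4 (`O/N=C1\CC2(N3CCCCC3)CC(c3ccccc3)C1C(c1ccccc1)C2`) departs from compound 3 in one place, with piperidin-1-yl in place of dimethylamino on a saturated ring carbon. With compound 3 at 150000 nM, the top of the measured range, a move to a lower number seems likelier than a move to a higher one, although this is an expectation without a direct precedent. A moderate change, beyond the scatter but smaller than the full spread of the measured compounds, is expected. The expected step is a 2.5-fold lower number from compound 3 to compound 4 (0.40 log units; beyond the scatter). For compound 4 the estimated value is 60000 nM, with an expected range from 20000 nM to 160000 nM.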

Compound 4, half-maximal inhibitory concentration: 24200 nM
Compound 4: middle estimate off by 2.5-fold (0.39 log units), on the high side, within the range that was stated.
By their numbers in this assay, from the lowest: compound 2; then compound 4; then compound 1; then compound 3.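

The exchange of dimethylamino for piperidin-1-yl on a saturated ring carbon gives a 6.2-fold lower number from compound 3 to compound 4 (0.79 log units; beyond the scatter) in this assay, the first direct measure of a single change in this set, and it shows that the number in this assay responds to the group carried at this place on the shared core. The entering group brings one six-membered non-aromatic ring and more heavy atoms, while the hydrogen-bond donor and acceptor counts and the absence of net charge stay as they were, so the step arises without any change in those counted features. No measurement is available that would explain the step.

The compounds shown leave open whether the step follows ring size or the ring itself, since a pyrrolidin-1-yl or morpholin-4-yl group, or an open-chain diethylamino group, at this place would be needed to separate these readings. They also leave open whether the same exchange would give a step of similar size on the core of compound 2, which carries a hydroxyl group and two 4-chlorophenyl groups.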